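A few compounds are considered here, and "the series" means these few. Any claim that something is new, unique, unknown or untested is made for them only; others in the source may bear on it.

Measured so far:
compound 1 `Cc1c(OCCCCOCOc2ccc(C(=O)O)cc2)ccc(C(=O)CC2CCCC2)c1O`: 95.4%
compound 2 `Cc1c(OCCCCOc2ccc(C(=O)C(C)C)c(O)c2C)cccc1C(=O)O`: 66.9%

In an assay on HEK293 cells for positive allosteric modulation of metabotropic glutamate receptor 2 (Rattus norvegicus), read by thallium flux, with a stated time of 2.5 min (on this read-out lower numbers stand for smaller maximal responses and higher numbers for larger maximal responses), compound 1 gives 95.4%, the higher of the two numbers on hand; compound 2 comes in a good way lower at 66.9%, a gap beyond the scatter. For the measured compounds named here, no pair of measured compounds differs in only one place, so no single step is known. Compound 3 `COc1ccc(C(=O)O)cc1OCCCCOc1ccc(C(=O)CC2CCCC2)c(O)c1C` is not yet measured; it differs from compound 1 as follows: 5-carboxy-2-methoxyphenyl in place of (4-carboxyphenoxy)methyl on an oxygen on a saturated carbon. Going by the values given here, with no comparable step recorded, the expected step of a number 10.4 percentage points lower from compound 1 to compound 3 (beyond the scatter) is small, downward if anything, and probably not beyond the scatter. Compound 3 is estimated at about 85%, in the range 62% to 104%.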

Compound 3, largest response reached (reported as percent of maximum), in percent of the reference or control that the assay uses: 91.8%
For compound 3 the middle estimate is 6.8 percentage points below the measured one; the measured number falls inside the stated range.
By their numbers in this assay, from the lowest: compound 2; then compounds 3 and 1 (each within the scatter of the next).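

In this assay, for the compounds shown here, the step is a number 3.6 percentage points lower from compound 1 to compound 3 (within the scatter), the first comparison that differs in one place. On an oxygen on a saturated carbon, 5-carboxy-2-methoxyphenyl and (4-carboxyphenoxy)methyl, which have the same atoms joined differently, cannot be told apart by maximal response. No supporting data bear on this result.

The compounds shown leave open whether this position keeps its response with a primary amide or a tetrazole in place of the carboxylic acid. As far as these compounds go, a longer chain on that oxygen also remains open.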